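Dropping the 3-methylbut-2-en-1-yl group from compound 2

A few compounds are considered here, and "the series" means these few. Any claim that something is new, unique, unknown or untested is made for them only; others in the source may bear on it.

Compound 1 `COc1ccc(/C=C/C(=O)c2c(OC)cc(O)c(CC=C(C)C)c2O)cc1OC` gives 13800 nM in a functional assay on HepG2 cells (Homo sapiens) for inhibition, read by MTT assay, with a stated time of 72 h; on this read-out lower numbers stand for stronger inhibition and higher numbers for weaker inhibition. Compound 2 `COc1cc(/C=C/C(=O)c2c(OC)cc(O)c(CC=C(C)C)c2O)cc(OC)c1OC` reaches only the limit > 50000 nM in this assay, so no number is known for it, as noted in the limit of > 50000 nM in this assay, at which 1 of the 2 values shown sits. Within the data shown here, the only measured step, an at least 3.6-fold higher number from compound 1 to compound 2 (0.55 log units; beyond the scatter), concerns a methoxy and not the change now in question. Compound 3 `COc1cc(/C=C/C(=O)c2c(O)cc(O)cc2OC)cc(OC)c1OC` differs from compound 2 by hydrogen in place of 3-methylbut-2-en-1-yl on an aromatic carbon. Among the measured compounds shown here, no measured step bears on this change, so no direction can be drawn from the series. Compound 3 is therefore expected to stay near the limit, estimated at 60000 nM with a range of 20000 nM to 200000 nM. The expected step is a step that the limit leaves unreadable from compound 2 to compound 3.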

Compound 3, half-maximal inhibitory concentration: 20400 nM
Estimate against measurement, compound 3: 2.9-fold (0.47 log units) above; the measured number falls inside the stated range.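

In this assay, among these compounds, hydrogen in place of 3-methylbut-2-en-1-yl gives an at least 2.4-fold lower number from compound 2 to compound 3 (0.38 log units; beyond the scatter), the first readable change at this position, which is ortho to two hydroxy groups. Within this pair, stronger inhibition therefore goes with hydrogen on this aromatic carbon, not with the 3-methylbut-2-en-1-yl group. The value of compound 2 is a limit and not a number, so the step has no exact size: the limit of > 50000 nM in this assay, at which 1 of the 3 values shown sits.

From the compounds shown here alone, whether the same change on compound 1 gives a similar step remains open. Also open, going by these compounds, is how a methyl group, a longer chain or an amine at this position would compare with hydrogen.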